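The source may hold more compounds than are shown below. What is called first, only, known or untested is meant among the compounds shown, and "the series" means these compounds.

In a functional assay on A549 cells (Homo sapiens) for cytotoxicity, read by MTT assay, with a stated time of 48 h (a higher number here means a weaker inhibitor, a lower number a stronger inhibitor), the trimethoxyphenyl cyclopropane series clusters in a narrow band. Compound 1, `CCOC(=O)C1(C(=O)Nc2ccc(F)cc2)CC1c1cc(OC)c(OC)c(OC)c1`, gives 22400 nM; 28000 nM (2 entries), and compound 3, `CCOC(=O)C1(C(=O)NCc2ccc(C)cc2)CC1c1cc(OC)c(OC)c(OC)c1`, gives 18700 nM; 21400 nM (2 entries); both were run more than once, as shown by the several entries of compound 1 in this assay, 22400 nM; 28000 nM (2 entries) and (the several entries of compound 3 in this assay, 18700 nM; 21400 nM (2 entries)), and their repeats sit close together. Within the data shown here, compound 2, `CCOC(=O)[C@@]1(C(=O)Nc2ccccc2Cl)C[C@H]1c1cc(OC)c(OC)c(OC)c1`, gives 17600 nM, the only number it has in this assay; two further entries for compound 2 returned no single number. On the numbers shown, compound 2 stands alongside compound 1 and compound 3 rather than apart from them.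

Compound 4, `CCOC(=O)[C@]1(C(=O)Nc2ccccc2Cl)C[C@H]1c1cc(OC)c(OC)c(OC)c1`, has not yet been measured in this assay. It differs from compound 2 as follows: the two compounds have the same atoms and bonds and differ only in configuration as drawn: 1 of 2 stereo elements differ; a stereocentre at a saturated ring carbon is drawn S in compound 2 and R in compound 4. Among the measured compounds shown here, with no measured pair of this kind to draw on, the step from compound 2 to compound 4 is expected to be small, in no fixed direction, and likely within the scatter; the estimated step is a 1.1-fold higher number from compound 2 to compound 4 (0.06 log units; within the scatter). Compound 4 is accordingly expected to give about 20000 nM, with a range from 8000 nM to 50000 nM.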

Compound 4, half-maximal inhibitory concentration: 13400 nM
Estimate against measurement, compound 4: 1.5-fold (0.17 log units) above; the range from low to high includes it.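

In this assay, the stereocentre at a saturated ring carbon, drawn S in one compound and R in the other, now has a measured step: a 1.3-fold lower number from compound 2 to compound 4 (0.12 log units; within the scatter). Among these compounds, the earlier compounds differed from one another in more than one place, so this is the first comparison that isolates a single change, and it shows that this inversion leaves the two compounds together within the scatter. A step of this size is comparable to the spread between repeat entries of a single compound: the several entries of compound 1 in this assay, 22400 nM; 28000 nM (2 entries).

The compounds shown leave open whether inverting the other stereocentre, or both at once, would give a larger step. They also leave open whether the configuration at this carbon would count for as little with a carboxylic acid in place of the ethyl ester.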